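The compounds below may be only part of what the source reports. "The series", "measured", "known", "first", "only" and "open" are said of these compounds alone.

Compound 1 `CC(C)NC(=O)N1CCN(C(=S)SCc2cn(Cc3ccccc3F)nn2)CC1` and compound 2 `CC(C)(C)NC(=O)N1CCN(C(=S)SCc2cn(Cc3ccccc3F)nn2)CC1` share one core, while compound 3 `CCNC(=O)N1CCN(C(=S)SCc2cn(Cc3ccc(C)cc3)nn2)CC1` and compound 4 `Cc1ccc(Cn2cc(CSC(=S)N3CCN(C(=O)NC(C)C)CC3)nn2)cc1` share another; the difference between the two cores is not broken down here. In a functional assay on MGC-803 cells (Homo sapiens) for cytotoxicity, read by MTT assay, with a stated time of 72 h (a lower number here means a stronger inhibitor, a higher number a weaker inhibitor), compound 1 gives 1620 nM. Compound 2, in this assay, gives 40700 nM. The change from compound 1 to compound 2 is methyl in place of hydrogen on a saturated chain carbon bound to an amide-type nitrogen and two saturated chain carbons, and it made a 25-fold higher number from compound 1 to compound 2 (1.40 log units; beyond the scatter). Compound 3 gives 19800 nM in this assay, a weaker result than compound 1 and a somewhat stronger one than compound 2.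

Compound 4 has not yet been measured. It differs from compound 3 by methyl in place of hydrogen on a saturated chain carbon bound to an amide-type nitrogen and a saturated chain carbon. For the measured compounds named here, this is the same kind of change as the one from compound 1 to compound 2, but the place is not identical: there the carbon was bound to an amide-type nitrogen and two saturated chain carbons, here it is bound to an amide-type nitrogen and a saturated chain carbon. The earlier step warns that adding a methyl at such a carbon can cost a great deal of potency. On the other hand, the isopropylcarbamoyl group that enters is the very group carried by compound 1, the strongest of the three measured compounds. With these two signals pulling in opposite directions, the expected step for compound 4 is much smaller than the earlier one, a 2.0-fold lower number from compound 3 to compound 4 (0.30 log units; within the scatter), and carries wide uncertainty. Compound 4 is estimated at 10000 nM, most likely between 2000 nM and 50000 nM.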

Compound 4, half-maximal inhibitory concentration: 16600 nM
The estimate for compound 4 lay 1.7-fold (0.22 log units) below the measured number; the measured number falls inside the stated range.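

In this assay, methyl in place of hydrogen on the saturated chain carbon bound to the amide-type nitrogen gives a 1.2-fold lower number from compound 3 to compound 4 (0.08 log units; within the scatter), so the large loss seen with the same kind of change on the core of compound 1 does not reappear on the core of compound 3. For the compounds shown here, the size of this kind of change on one core therefore cannot be taken as a guide to its size on the other: the same change on two cores in this assay, a 25-fold higher number (1.40 log units; beyond the scatter) from compound 1 to compound 2 and a 1.2-fold lower number (0.08 log units; within the scatter) from compound 3 to compound 4, 30-fold (1.48 log units) apart, beyond the scatter of two such steps This does not show what causes the gap, as the two steps differ in the carbon that carries the methyl as well as in the core, and the only direct look at the core difference is the step with the isopropylcarbamoyl group held fixed, where 4-methylphenyl in place of 2-fluorophenyl gives a 10-fold higher number from compound 1 to compound 4 (1.01 log units; beyond the scatter).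

The compounds shown leave open how the tert-butylcarbamoyl group would behave on the core of compound 3, and how the ethylcarbamoyl group would behave on the core of compound 1. They also leave open whether a cyclopropyl ring or a longer chain such as n-butyl on the carbamoyl nitrogen would follow either core's trend.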